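The source may hold more compounds than are shown below. What is called first, only, known or untested is meant among the compounds shown, and "the series" means these compounds.

Compound 1 `O=C(NCc1ccc(CNS(=O)(=O)c2ccc([N+](=O)[O-])cc2)cc1)c1ccc(F)cc1` is the starting point. Going by the values given here, in an assay on MDA-MB-231 cells for binding affinity to C-X-C chemokine receptor type 4 (Homo sapiens), read by fluorescence and microscopy, with stated times of 10 min and 30 min (a lower number here means that less compound is needed, a higher number that more compound is needed for the effect), compound 1 gives 1000 nM, the highest of the two numbers measured so far. Compound 2 `Cc1ccccc1S(=O)(=O)NCc1ccc(CNC(=O)c2ccc(F)cc2)cc1` gives 100 nM in this assay, and the step of a 10-fold lower number from compound 1 to compound 2 (1.00 log units; beyond the scatter) shows that exchanging the aryl group on the sulfonyl sulfur moves the read-out well beyond the scatter. Compound 3 `O=C(NCc1ccc(CNS(=O)(=O)c2ccc(-c3ccc(F)cc3)cc2)cc1)c1ccc(F)cc1` has not been measured. It differs from compound 1 in one place: 4-fluorophenyl in place of nitro on an aromatic carbon. Among the compounds with values here, only the step from compound 1 to compound 2 bears on this change, since it also alters the aryl group on the sulfonyl sulfur, though there the whole ring was swapped rather than one substituent on it. Given a 10-fold lower number from compound 1 to compound 2 (1.00 log units; beyond the scatter), a change at this part of the molecule is expected to shift the number, most likely towards a lower value, with wide uncertainty. Compound 3 is therefore estimated at 500 nM, between 100 nM and 2500 nM, which would be a step of a 2.0-fold lower number from compound 1 to compound 3 (0.30 log units; within the scatter).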

Compound 3, effective concentration (reported as EC, without a stated level of effect): 100 nM
For compound 3 the middle estimate is 5.0-fold (0.70 log units) above the measured one; low and high end bracket the measured number.
By their numbers in this assay, from the lowest: compounds 2 and 3 (each within the scatter of the next); then compound 1.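

In this assay, the exchange of nitro for 4-fluorophenyl gives a 10-fold lower number from compound 1 to compound 3 (1.00 log units; beyond the scatter), so a change at this one place, para to a large group, is enough to move the number beyond the scatter. The earlier step, a 10-fold lower number from compound 1 to compound 2 (1.00 log units; beyond the scatter), replaced the whole aryl group on the sulfonyl sulfur and could not show this, whereas here that ring stays and only its substituent differs. Nothing available accounts for this shift in terms of a cause.

The pair cannot separate what the loss of nitro contributes from what the arrival of 4-fluorophenyl contributes, since both happen in the same step. From the compounds shown here alone, how an unsubstituted phenyl, a methoxy group, an amine or a carboxylic acid would read at this place remains open.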